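Replacing a Pentyl Chain with a Thiophene Bearing Group

A few compounds are considered here, and "the series" means these few. Any claim that something is new, unique, unknown or untested is made for them only; others in the source may bear on it.

Of the compounds shown here, three have been measured in an assay on membranes from Sf9 cells for displacement of a labelled ligand from histamine H2 receptor (Homo sapiens), read by scintillation counting, with a stated time of 60 min; on this read-out higher numbers stand for weaker inhibition and lower numbers for stronger inhibition. Compound 1 `CCCNC(=O)/N=C(\N)Nc1cccc(-c2csc(N)n2)c1` gives 5250 nM in this assay. Compound 2 `Cc1nc(N)sc1CCCN/C(N)=N/C(=S)NC(c1ccccc1)c1ccccc1` gives 603 nM. Compound 3 `CCCCCNC(=O)/N=C(\N)NCCCc1sc(N)nc1C` gives 4.47 nM, the lowest of the three numbers, and therefore the strongest inhibitor among them, with the gaps to compound 2 and to compound 1 both beyond the usual scatter.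

Compound 4 `Cc1nc(N)sc1CCCN/C(N)=N/C(=O)NC(C)c1cccs1` is not yet measured. It differs from compound 3 in one place: 1-(thiophen-2-yl)ethyl in place of pentyl on an amide-type nitrogen. The pentyl chain on the amide-type nitrogen is replaced by a longer group that carries a five-membered aromatic ring with one hetero atom and one hydrogen-bond acceptor.

Within the data shown here, no measured pair shows this kind of change, so the direction of the step cannot be read from the data. Compound 3 holds the strongest value here, which leaves more room for a loss than for a gain. The step from compound 3 to compound 4 in this assay is expected to be a modest weakening, a 3.4-fold higher number from compound 3 to compound 4 (0.53 log units; beyond the scatter). Compound 4 is estimated at 15 nM, within a range from 3 nM to 80 nM.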

Compound 4, inhibition constant: 63.1 nM
Compound 4: the middle estimate sits 4.2-fold (0.62 log units) below what was measured, and the stated range covers the measured number.
By their numbers in this assay, from the lowest: compound 3; then compound 4; then compound 2; then compound 1.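

Among these compounds, compound 3 and compound 4 form the first pair here that differs in only one place, so the effect of a change on the amide-type nitrogen can now be read directly. In this assay, putting 1-(thiophen-2-yl)ethyl in place of pentyl gives a large loss (a 14-fold higher number from compound 3 to compound 4 (1.15 log units; beyond the scatter)), which shows that this position is sensitive to the group it carries and that, in this one case, the ring-bearing group does worse than the plain chain. No measurement shown here explains this loss.

This single step cannot tell whether the thiophene ring or the methyl-bearing carbon linking it to the nitrogen matters more. A thiophen-2-ylmethyl group or a hexyl chain on the same nitrogen would bear on that question.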